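Benzyl for isopropyl on the ring nitrogen

The compounds below may be only part of what the source reports. "The series", "measured", "known", "first", "only" and "open" are said of these compounds alone.

Measured compounds:
compound 1 `CC(C)n1nc(S(=O)(=O)c2cccc3ccccc23)c2cc(N3CCN(C)CC3)ccc21` — 98%
compound 2 `Cc1ccc(S(=O)(=O)c2n[nH]c3ccc(N4CCN(C)CC4)cc23)cc1` — 100%

In a functional assay on HeLa cells for antagonist activity at 5-hydroxytryptamine receptor 6 (Homo sapiens) (on this read-out higher numbers stand for larger maximal responses and lower numbers for smaller maximal responses), compound 1 gives 98%, and compound 2 gives 100%. The two values lie within the usual scatter of each other, so neither compound can be placed above the other; both reach essentially the full response of the reference. Going by the values given here, compound 2 differs from compound 1 in several places at once, so the pair offers no single step to read from.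

Compound 3 `CN1CCN(c2ccc3c(c2)c(S(=O)(=O)c2cccc4ccccc24)nn3Cc2ccccc2)CC1` is the next compound to be tested in this assay. It differs from compound 1 in one place: benzyl in place of isopropyl on an aromatic nitrogen. The change is confined to the group on the aromatic nitrogen; everything else of the shared core stays as in compound 1.

With both measured compounds already at the top of the scale, the expected step of a number 1 percentage points lower from compound 1 to compound 3 (within the scatter) is none beyond the scatter, in no particular direction. For compound 3 the largest response in this assay is estimated at 97%, expected to fall between 85% and 105%.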

Compound 3, largest response reached (reported as Imax), in percent of the reference or control that the assay uses: 100%
Beside the measured number, compound 3's estimate is 3 percentage points below it; low and high end bracket the measured number.
By their numbers in this assay, from the lowest: compounds 1, 2 and 3 (each within the scatter of the next).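

In this assay, going by these compounds alone, benzyl in place of isopropyl on the aromatic nitrogen gives a number 2 percentage points higher from compound 1 to compound 3 (within the scatter) and this is the only step so far that can be read at a single place. The position therefore carries benzyl, with 7 heavy atoms and a six-membered aromatic ring, as well as isopropyl, with 3 heavy atoms and no ring, and the largest response shows no difference that can be told from the scatter. Nothing at hand offers an explanation for this result.

A group on this nitrogen that carries an amine or a carboxylic acid, or a longer chain, remains an open case. Also open, from the compounds shown here alone, is whether any group at this position can bring the largest response clearly away from the level shared by compound 1 and compound 3.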